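Swapping a halogen on the phenoxy ring: chloro to bromo

The compounds below may be only part of what the source reports. "The series", "measured", "known", "first", "only" and "open" are said of these compounds alone.

Of the compounds shown here, three of one shared core have been measured in a functional assay on SGC-7901 cells (Homo sapiens) for antiproliferative activity, read by MTT assay, with a stated time of 72 h; a lower number here means a stronger inhibitor, a higher number a weaker inhibitor. Compound 1 `Cc1nn(C)c(Oc2ccc(Cl)cc2)c1/C=N\OCc1c(Cl)c(-c2ccc(F)cc2)nn1C` gives 8110 nM. Compound 2 `Cc1nn(C)c(Oc2ccc(F)cc2)c1/C=N\OCc1c(Cl)c(-c2ccc(Cl)cc2)nn1C` gives 4430 nM. Compound 3 `Cc1nn(C)c(Oc2ccc(Cl)cc2)c1/C=N\OCc1c(Cl)c(-c2ccc(Cl)cc2)nn1C` gives 7510 nM, which puts it second highest of the three numbers, with compound 1 nearest and compound 2 furthest, both within the scatter of the method.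

Compound 4 `Cc1nn(C)c(Oc2ccc(Br)cc2)c1/C=N\OCc1c(Cl)c(-c2ccc(Cl)cc2)nn1C` differs from compound 3 in one place: bromo in place of chloro on an aromatic carbon. The two measured steps that bear on this are also single halogen swaps on an aromatic carbon. From compound 1 to compound 3 the change was a 1.1-fold lower number from compound 1 to compound 3 (0.03 log units; within the scatter), and from compound 2 to compound 3 it was a 1.7-fold higher number from compound 2 to compound 3 (0.23 log units; within the scatter); neither moved beyond the scatter. Since the step to compound 4 is a swap of the same kind, the expected change in this assay is a 1.1-fold lower number from compound 3 to compound 4 (0.03 log units; within the scatter), that is, none beyond the scatter. Compound 4 is therefore estimated at 7000 nM, with a range from 3500 nM to 14000 nM.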

Compound 4, half-maximal inhibitory concentration: 5960 nM
The estimate for compound 4 lay 1.2-fold (0.07 log units) above the measured number; low and high end bracket the measured number.
By their numbers in this assay, from the lowest: compounds 2, 4, 3 and 1 (each within the scatter of the next).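

Bromo adds a third halogen at this place on the phenoxy ring, and in this assay the change from chloro gives a 1.3-fold lower number from compound 3 to compound 4 (0.10 log units; within the scatter) while the change from fluoro gives a 1.3-fold higher number from compound 2 to compound 4 (0.13 log units; within the scatter). For the compounds shown here, with the 4-chlorophenyl group held fixed, fluoro, chloro and bromo at this place therefore cannot be told apart in this measurement, whereas the earlier compounds could show this only for fluoro and chloro. No data here bear on why these three halogens read alike.

As far as these compounds go, all three compounds carry a halogen at this place, so it stays open whether a plain hydrogen, a methoxy group, an amine or a carboxylic acid there would move the number beyond the scatter. From the compounds shown here alone, it also stays open whether bromo would read the same in combination with the fluoro-bearing aryl group of compound 1.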